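Ethylamino Analogue Expected to Track Its Parent

The source may hold more compounds than are shown below. What is called first, only, known or untested is meant among the compounds shown, and "the series" means these compounds.

Three compounds were measured in a functional assay on the whole organism with Rattus norvegicus as the target, at a dose of 40 mg/kg by the intraperitoneal route; on this read-out higher numbers stand for more inhibition at the one dose given (going by the name of the read-out) and lower numbers for less inhibition. Compound 1 `Cc1nc2c(OCc3ccccc3)cccn2c1N` gives 99% in this assay, and compound 3 `CCNc1c(C)nc2c(OCc3ccccc3)cccn12` gives 95%. Compound 3 differs from compound 1 by ethyl in place of hydrogen on a nitrogen on an aromatic ring, and the step is a number 4 percentage points lower from compound 1 to compound 3 (within the scatter). Compound 2 `Cc1nc2c(OCc3ccccc3)nccn2c1N` gives 79% in this assay; the difference between its core and the core of compound 1 is not broken down here. Compound 2 stands lowest of the three, with its gaps to compound 3 and to compound 1 both beyond the scatter.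

Compound 4 `CCNc1c(C)nc2c(OCc3ccccc3)nccn12` has not yet been measured. It differs from compound 2 by ethyl in place of hydrogen on a nitrogen on an aromatic ring, the same change, at the same kind of place, that separates compound 3 from compound 1. Because that earlier step was a number 4 percentage points lower from compound 1 to compound 3 (within the scatter), the step from compound 2 to compound 4 is expected to be small as well, estimated at a number 3 percentage points lower from compound 2 to compound 4 (within the scatter). On that basis compound 4 is expected to give about 76% in this assay, with a range from 60% to 90%.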

Compound 4, a percentage reported as inhibition, in the whole organism at one dose (the size of the read-out at that dose, not a potency): 48%
Estimate against measurement, compound 4: 28 percentage points above, outside the stated range (below it).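

On the core of compound 2, ethyl in place of hydrogen on the nitrogen does not behave as it did on the core of compound 1: in this assay the change gives a number 31 percentage points lower from compound 2 to compound 4 (beyond the scatter), and it cannot be carried from one core to the other as a fixed amount. The two steps set side by side differ: the same change on two cores in this assay, a number 4 percentage points lower (within the scatter) from compound 1 to compound 3 and a number 31 percentage points lower (beyond the scatter) from compound 2 to compound 4, 27 percentage points apart, beyond the scatter of two such steps. Going by these compounds alone, this shows that, in these two pairs, the size of the amino to ethylamino step depends on the core, but it rests on only two pairs and does not show why the cores part ways or what the change would do on a third core.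

The compounds shown leave open whether a longer chain such as propyl on that nitrogen would follow the same split between the two cores. They also leave open whether an acetyl group there would do so, and whether the gap between the steps would hold at other doses.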